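Swapping the anilino aryl group of compound 3 for a fluoropyridine

The compounds below may be only part of what the source reports. "The series", "measured", "known", "first", "only" and "open" are said of these compounds alone.

Measured compounds:
- compound 1, `CCS(=O)(=O)Nc1cc(-c2ccc3ncnc(Nc4ccc(OC(F)(F)F)cc4)c3c2)cnc1OC`, 16600 nM
- compound 2, `CCS(=O)(=O)Nc1cc(-c2ccc3ncnc(Nc4ccc(OC)c(Cl)c4)c3c2)cnc1OC`, 5620 nM
- compound 3, `CCS(=O)(=O)Nc1cc(-c2ccc3ncnc(Nc4ccc(F)c(C(=O)OC)c4)c3c2)cnc1OC`, 2360 nM

All three compounds share one core and differ only in the aryl group carried on a nitrogen on an aromatic ring. In a functional assay on HCT-116 cells (Homo sapiens) for cytotoxicity, read by sulforhodamine B assay, with a stated time of 72 h (on this read-out lower numbers stand for stronger inhibition and higher numbers for weaker inhibition), compound 3 gives the lowest number of the three; compound 2 sits a 2.4-fold lower number from compound 2 to compound 3 (0.38 log units; beyond the scatter) and compound 1 sits a 7.0-fold lower number from compound 1 to compound 3 (0.85 log units; beyond the scatter).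

Compound 4, `CCS(=O)(=O)Nc1cc(-c2ccc3ncnc(Nc4ccc(F)nc4)c3c2)cnc1OC`, has not been measured. It differs from compound 3 by 6-fluoropyridin-3-yl in place of 4-fluoro-3-(methoxycarbonyl)phenyl on a nitrogen on an aromatic ring.

For the measured compounds named here, no measured step covers this particular exchange. What the measured steps do show is that changing the aryl group at this same place moves the number by modest amounts: a 3.0-fold lower number from compound 1 to compound 2 (0.47 log units; beyond the scatter), a 7.0-fold lower number from compound 1 to compound 3 (0.85 log units; beyond the scatter) and a 2.4-fold lower number from compound 2 to compound 3 (0.38 log units; beyond the scatter). Since compound 3 already gives the lowest number, and the group that enters carries less than the group that leaves, a modest move toward a higher number is expected, a 3.0-fold higher number from compound 3 to compound 4 (0.47 log units; beyond the scatter). The estimate for compound 4 in this assay is 7000 nM, within a range from 2000 nM to 25000 nM.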

Compound 4, half-maximal inhibitory concentration: 7620 nM
Estimate against measurement, compound 4: 1.1-fold (0.04 log units) below; the range from low to high includes it.
By their numbers in this assay, from the lowest: compound 3; then compounds 2 and 4 (each within the scatter of the next); then compound 1.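

In this assay, the step to the 6-fluoropyridin-3-yl group (a 3.2-fold higher number from compound 3 to compound 4 (0.51 log units; beyond the scatter)) leaves compound 3 with the lowest number of the four, so losing the 4-fluoro-3-(methoxycarbonyl)phenyl group gives up ground at this position. Even so, a ring holding a hetero atom is accepted here: compound 4 cannot be told apart from compound 2 (a 1.4-fold higher number from compound 2 to compound 4 (0.13 log units; within the scatter)) and still improves on the 4-(trifluoromethoxy)phenyl group (a 2.2-fold lower number from compound 1 to compound 4 (0.34 log units; beyond the scatter)). No measurement shown here explains these shifts.

From the compounds shown here alone, compound 4 changes the ring and removes the methoxycarbonyl group together, so the share of each in the step remains open. Also open, going by these compounds, is how a carboxylic acid or a primary amide would read in place of the methoxycarbonyl group on the ring of compound 3.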